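The source may report more compounds than this note shows. Statements on the series, on what has been measured and on what is new or still open speak of the compounds shown alone.

Measured so far:
compound 1, `Cc1ccc(C2CCN(S(=O)(=O)c3c(C)cc(C)cc3C)CC2)cc1`: 2200 nM
compound 2, `CC1CCN(C2CCN(S(=O)(=O)c3cccc4cnccc34)CC2)CC1`: 225 nM
compound 3, `CC1CCN(C2CCN(S(=O)(=O)c3ccccc3-c3ccccc3)CC2)CC1`: 0.96 nM

All three were read in a functional assay on DLD-1 cells (Homo sapiens) for antiproliferative activity, read by CellTiter-Glo, with a stated time of 72 h; a higher number here means a weaker inhibitor, a lower number a stronger inhibitor. Compound 1 gives the highest number of the three; its gap to compound 2 and its gap to compound 3 both lie beyond the scatter, so compound 1 is the weakest of the set. Compounds 2 and 3 show that far stronger inhibition is reachable from this core, though each differs from compound 1 in more than one place.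

Compound 4, `Cc1cc(C)c(S(=O)(=O)N2CCC(C3OCC(C)CO3)CC2)c(C)c1`, has not yet been measured. It differs from compound 1 in one place: a group of 7 heavy atoms (5 carbon, 2 oxygen; one six-membered non-aromatic ring with 2 hetero atoms) in place of a group of 7 heavy atoms (7 carbon; one six-membered aromatic ring of carbon only), on a saturated ring carbon The exchange sits on the saturated ring carbon, the same place where compounds 2 and 3 carry their own group.

Among the compounds with values here, no pair of measured compounds differs in a single place, so no measured step is at hand to gauge this exchange. The step from compound 1 to compound 4 is expected to be small and, if anything, toward a weaker inhibitor, roughly at the edge of the scatter: a 1.8-fold higher number from compound 1 to compound 4 (0.26 log units; within the scatter). For compound 4 the estimate in this assay is 4000 nM, with a range from 1200 nM to 15000 nM.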

Compound 4, half-maximal inhibitory concentration: > 5000 nM
Compound 4: no number, only a limit; the forecaster's own chance of this, stated with the estimate: 25%; at least 1.2-fold (0.09 log units) between middle value and limit.
By their numbers in this assay, from the lowest: compound 3; then compound 2; then compound 1. At a limit, above all of these: compound 4.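

In this assay, within the data shown here, the exchange of 4-methylphenyl for the six-membered non-aromatic ring with 2 hetero atoms, on the saturated ring carbon, gives an at least 2.2-fold higher number from compound 1 to compound 4 (0.35 log units; beyond the scatter) and so provides the first single-place step. From the compounds shown here alone, compound 4 carries a limit and not a number, so this step fixes only the lower bound of the loss, and its full size stays unknown. A group of the same heavy-atom count therefore does not hold the level of compound 1 at this position, and this reading rests on a limit: the limit of > 5000 nM in this assay, at which 1 of the 4 values shown sits.

Going by these compounds, whether an amine or a carboxylic acid on this saturated ring carbon would recover the level of compound 1 stays open. Also open, on these data alone, is how the same exchange would read with the sulfonyl groups of compounds 2 and 3.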